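Chain shortening on a second core: compound 4

The source may report more compounds than this note shows. Statements on the series, on what has been measured and on what is new or still open speak of the compounds shown alone.

Two compounds share one core: compound 1 `CCCCCCCCCCCCCCCCc1c(C)c(N(C)C)nc(C)c1O` and compound 2 `CCCCCCCCCCCCCCCCCCCc1c(C)c(N(C)C)nc(C)c1O`. In a functional assay on cells (Lymphocyte, Homo sapiens), read by trypan blue exclusion, with a stated time of 16 h, tested at 2.5 uM (on this read-out higher numbers stand for a stronger effect at the one concentration tested and lower numbers for a weaker effect), compound 2 gives 87%, and compound 1 gives 85%. The change from compound 2 to compound 1 is hydrogen in place of propyl on a saturated chain carbon, ten or more bonds along the chain from an aromatic carbon; the step it made was a number 2 percentage points lower from compound 2 to compound 1 (within the scatter).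

Compound 3 `CCCCCCCCCCCCCCCCCCCc1nc(N(C)C)c(C)c(C)c1O` carries the same atoms as compound 2, joined differently; the difference between the two cores is not broken down here. In this assay compound 3 gives 66%, which leaves it lowest of the three numbers, beyond the scatter from both compound 1 and compound 2.

Compound 4 `CCCCCCCCCCCCCCCCc1nc(N(C)C)c(C)c(C)c1O` is not yet measured. Its change from compound 3 is hydrogen in place of propyl on a saturated chain carbon, ten or more bonds along the chain from an aromatic carbon, the same change that took compound 2 to compound 1, at the same place. Since compound 3 gives 66% and the earlier step was within the scatter, the step from compound 3 to compound 4 is expected to be a number 2 percentage points lower from compound 3 to compound 4 (within the scatter). On that basis compound 4 is estimated at 64% in this assay, roughly between 50% and 78%.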

Compound 4, a percentage reported as activity, at one concentration (the size of the read-out at that concentration, not a potency): 83%
The estimate for compound 4 lay 19 percentage points below the measured number; measured number outside the range, above it.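

Hydrogen in place of propyl on a saturated chain carbon gives a number 17 percentage points higher from compound 3 to compound 4 (beyond the scatter) in this assay. The same change therefore does not carry over with the same result from one core to the other: the same change on two cores in this assay, a number 2 percentage points lower (within the scatter) from compound 2 to compound 1 and a number 17 percentage points higher (beyond the scatter) from compound 3 to compound 4, 19 percentage points apart, beyond the scatter of two such steps. For this series, a step measured on one core cannot be taken as the step on the other, but a single matched pair on each core does not show why the two differ, nor whether the difference would hold for other chain lengths or other cores.

The compounds shown leave open how the read-out runs along a wider range of chain lengths on each core, for instance with a much shorter chain such as octyl. They also leave open whether a chain ending in a carboxylic acid or an amine would behave as on the core of compound 1 or as on the core of compound 3.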